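Swapping a Short Chain for a Bromophenyl Ring

This account rests on a few compounds, and the source may have more. Where it says the series, first, only, none or still open, it means among the compounds named here.

Compound 3 `O=C1O[C@H]([C@@H](O)Cn2cc(CCO)nn2)C(OCc2ccccc2)=C1OCc1ccccc1` was tested in a functional assay on CFPAC-1 cells (Homo sapiens) for antiproliferative activity, read by MTT assay, with a stated time of 72 h; on this read-out higher numbers stand for weaker inhibition and lower numbers for stronger inhibition. In this assay compound 3 gives only a limit, > 100000 nM. Compound 1 `Cc1ccc(-c2cn(C/C=C3\OC(=O)C(OCc4ccccc4)=C3OCc3ccccc3)nn2)cc1`, built on a different core, likewise gives only a limit, > 100000 nM. Among the measured compounds shown here, compound 2 `O=C1O[C@H]([C@@H](O)Cn2cc(CNS(=O)(=O)c3ccc(Cl)cc3F)nn2)C(OCc2ccccc2)=C1OCc1ccccc1`, the single compound with a measured number, gives 58200 nM. For the measured compounds named here, the one measured step, an at least 1.7-fold higher number from compound 2 to compound 3 (0.23 log units; that floor lies within the scatter), points toward weaker inhibition but stays within the scatter. Compound 4 `O=C1O[C@H]([C@@H](O)Cn2cc(-c3ccc(Br)cc3)nn2)C(OCc2ccccc2)=C1OCc1ccccc1` differs from compound 3 by 4-bromophenyl in place of 2-hydroxyethyl on an aromatic carbon. Going by the values given here, no measured step covers this change; the only evidence is the limit of > 100000 nM in this assay, at which 2 of the 3 values shown sit, so another limit is likely and no shift beyond the scatter is expected. Compound 4 is estimated at 90000 nM, in a range from 30000 nM to 300000 nM, an expected step of an at least 1.1-fold lower number from compound 3 to compound 4 (0.04 log units; that floor lies within the scatter).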

Compound 4, half-maximal inhibitory concentration: 5830 nM
For compound 4 the middle estimate is 15-fold (1.19 log units) above the measured one; the measured number lies below the stated range.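

In this assay, 4-bromophenyl in place of 2-hydroxyethyl on this aromatic carbon brings an at least 17-fold lower number from compound 3 to compound 4 (1.23 log units; beyond the scatter), the only step shown that lies beyond the scatter, so this position can strongly change the read-out. That size is only a floor: compound 3 gives a limit, not a number. Compound 4 stands apart from the limits common in this small set: the limit of > 100000 nM in this assay, at which 2 of the 4 values shown sit.

The change replaces the chain with a ring and also adds bromine, so the compounds shown cannot separate these two parts. Plain phenyl, 4-chlorophenyl or an amine on this carbon remains an open comparison.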